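Hydroxy for fluoro on the phenoxy ring of compound 3

The compounds below may be only part of what the source reports. "The series", "measured", "known", "first", "only" and "open" are said of these compounds alone.

Working notes on the series. Compound 1 `CN(Cc1ccc(OCCCN)cc1)c1nc2ccc(Oc3ccc(C#N)cc3)cc2s1` gives 65000 nM in an assay on SH-SY5Y cells for inhibition of Voltage-dependent N-type calcium channel subunit alpha-1B (Homo sapiens), read by FLIPR and calcium flux, with stated times of 600 s and 300 s, in the presence of a further agent that is not named here; on this read-out higher numbers stand for weaker inhibition and lower numbers for stronger inhibition. Compound 3 `CN(Cc1ccc(OCCCN)cc1)c1nc2ccc(Oc3ccc(F)cc3)cc2s1` gives 98000 nM in this assay, the second highest of the three numbers measured; the step of a 1.5-fold higher number from compound 1 to compound 3 (0.18 log units; within the scatter) corresponds to fluoro in place of cyano on an aromatic carbon. Compound 2 `NCCCOc1ccc(CNc2nc3ccc(Oc4ccc(O)cc4)cc3s2)cc1`, which carries the hydroxy group but lacks the methyl on the amine, gives 205000 nM in this assay, a number beyond the scatter above that of compound 3. Compound 4 `CN(Cc1ccc(OCCCN)cc1)c1nc2ccc(Oc3ccc(O)cc3)cc2s1` differs from compound 3 by hydroxy in place of fluoro on an aromatic carbon. Within the data shown here, no measured step reproduces this single change. Among the measured compounds shown here, the only step measured on this ring, a 1.5-fold higher number from compound 1 to compound 3 (0.18 log units; within the scatter), stays within the scatter, while the values of compound 2 and compound 3 lie apart by more than the scatter but with two changes between them. Compound 4 is therefore expected to give 150000 nM in this assay, with a range of 70000 nM to 320000 nM. The expected step of a 1.5-fold higher number from compound 3 to compound 4 (0.18 log units; within the scatter) is a modest move toward weaker inhibition, not assured to exceed the scatter.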

Compound 4, half-maximal inhibitory concentration: 117000 nM
The estimate for compound 4 lay 1.3-fold (0.11 log units) above the measured number; the range from low to high includes it.
By their numbers in this assay, from the lowest: compounds 1, 3, 4 and 2 (each within the scatter of the next, the first and the last beyond it).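

In this assay the aromatic carbon para to a large group now carries three different groups, and neither a 1.2-fold higher number from compound 3 to compound 4 (0.08 log units; within the scatter) nor a 1.8-fold higher number from compound 1 to compound 4 (0.26 log units; within the scatter) leaves the scatter, so hydroxy, with its hydrogen-bond donor, reads no differently here from fluoro or cyano. Methyl on the nitrogen can now be read as a single change, and a 1.8-fold lower number from compound 2 to compound 4 (0.24 log units; within the scatter) also stays within the scatter, where the earlier compounds offered only a gap with two changes in it. No measurement is at hand that would explain these small steps.

An amine, a carboxylic acid or a methoxy group on this carbon could show whether any group here moves the number beyond the scatter. As far as these compounds go, whether fluoro and cyano give the same reading without the methyl on the nitrogen stays open.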